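The compounds below may be only part of what the source reports. "The series", "measured", "known", "first", "only" and "open" are said of these compounds alone.

Three compounds sharing one core were tested in an assay on HEK293 cells for displacement of a labelled ligand from corticotropin-releasing factor receptor 1 (Homo sapiens), with a stated time of 2 h; on this read-out lower numbers stand for stronger inhibition and higher numbers for weaker inhibition. Compound 1 `COCc1cc(OC)c(-c2nc3c(C)ccc(N(C)C)c3cc2C)c(OC)c1` gives 212 nM. For compound 2 `COCCNc1ccc(C)c2nc(-c3c(OC)cc(COC)cc3OC)c(C)cc12` the assay reports only a limit, > 1000 nM, and the limit of > 1000 nM in this assay, at which 1 of the 3 values shown sits, records that this is a limit rather than a number. Going by the values given here, the one step that can be sized, an at least 4.7-fold higher number from compound 1 to compound 2 (0.67 log units; beyond the scatter), concerns the amine group on the core. Compound 3 `CCN(CC)c1ccc(C)c2nc(-c3c(OC)cc(COC)cc3OC)ccc12` gives 184 nM, the lower of the two numbers shown, yet compound 1 sits within the scatter of it, so the two cannot be ranked against each other.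

The next compound, compound 4 `CCN(CC)c1ccc(C)c2nc(-c3c(OC)cc(COC)cc3OC)c(F)cc12`, differs from compound 3 by fluoro in place of hydrogen on an aromatic carbon. Among the compounds with values here, no measured step touches this kind of exchange on the core ring: the single sized step, from compound 1 to compound 2, changes the amine and offers no guide for a fluoro in place of hydrogen. With nothing pointing either way, the expectation for compound 4 in this assay is a step of a 1.0-fold lower number from compound 3 to compound 4 (0.01 log units; within the scatter), that is, no change beyond the scatter. Compound 4 is therefore estimated at 180 nM, expected to fall between 60 nM and 550 nM.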

Compound 4, half-maximal inhibitory concentration: 144 nM
Estimate against measurement, compound 4: 1.3-fold (0.10 log units) above, within the range that was stated.
By their numbers in this assay, from the lowest: compounds 4, 3 and 1 (each within the scatter of the next). At a limit, above all of these: compound 2.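

In this assay, going by these compounds alone, the new pair gives the only reading so far for a change on an aromatic carbon two atoms from the ring nitrogen and ortho to a large group: a 1.3-fold lower number from compound 3 to compound 4 (0.11 log units; within the scatter). The earlier sized step concerned only the amine group, so it said nothing about this carbon; here, a single fluorine atom can replace hydrogen without any difference that stands clear of the usual variation between repeated measurements. Nothing in the data shown explains this outcome or bears on it.

From the compounds shown here alone, one small atom at one carbon is a narrow test, so it remains open whether chloro, trifluoromethyl or a nitrile on this same carbon would also stay within the scatter of compound 3 or would move the number beyond it. It is also open whether fluoro in place of hydrogen would read the same way with a different amine on the shared core, such as a pyrrolidine or a morpholine, since this exchange is shown with only one amine.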